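Hydroxy on the core: from compound 1 to compound 3

The source may hold more compounds than are shown below. What is called first, only, known or untested is meant among the compounds shown, and "the series" means these compounds.

Measured in an assay on isolated protein for inhibition of Indoleamine 2,3-dioxygenase 1 (Homo sapiens), read by spectrophotometry; a lower number here means a stronger inhibitor, a higher number a weaker inhibitor:
compound 1 `O=C(Cc1cccnc1)c1cc2ccccc2[nH]1` gives 65000 nM
compound 2 `O=C(Cc1ccccn1)c1cc2ccccc2[nH]1` gives 37000 nM

Compound 1 carries pyridin-3-yl on the saturated chain carbon bound to the carbonyl carbon and stands at the highest of the two numbers; the nearest number is a 1.8-fold lower number from compound 1 to compound 2 (0.24 log units; within the scatter), within the scatter, so the two values cannot be told apart. Compound 3 `O=C(Cc1cccnc1)c1cc2cc(O)ccc2[nH]1` has not been measured in this assay. It differs from compound 1 by hydroxy in place of hydrogen on an aromatic carbon, a change on the core rather than on the chain. Going by the values given here, no measured step touches the core: the single step in hand, a 1.8-fold lower number from compound 1 to compound 2 (0.24 log units; within the scatter), alters only the pyridyl attachment and gives no guidance on a hydroxy on the core. With nothing to point either way, the expected step of a 1.3-fold lower number from compound 1 to compound 3 (0.11 log units; within the scatter) is none beyond the scatter. Compound 3 is therefore estimated at 50000 nM in this assay, with a range of 15000 nM to 170000 nM.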

Compound 3, half-maximal inhibitory concentration: 37000 nM
Beside the measured number, compound 3's estimate is 1.4-fold (0.13 log units) above it, within the range that was stated.
By their numbers in this assay, from the lowest: compounds 2, 3 and 1 (each within the scatter of the next).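

In this assay, going by these compounds alone, the first change on the core, hydroxy in place of hydrogen on an aromatic carbon, gives a 1.8-fold lower number from compound 1 to compound 3 (0.24 log units; within the scatter) and so cannot be told apart from no effect. Where the earlier pair spoke only to the pyridyl attachment on the chain, this result shows that a hydroxy can sit on this carbon, meta to a fused ring and para to a fused ring, without a readable shift in the number. No supporting measurement bears on this result.

Open, on these data alone, is whether a methoxy, an amine or a carboxylic acid on the same carbon would give a step beyond the scatter. Also open, as far as these compounds go, is whether the hydroxy would behave the same way with the pyridin-2-yl group of compound 2 on the chain.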